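The source may hold more compounds than are shown below. What is called first, only, known or untested is meant among the compounds shown, and "the series" means these compounds.

Measured compounds: compound 1 `COc1ccc(-c2nc(CNc3ccc(C(=O)NO)cc3)n(-c3ccccc3)n2)cc1` with 77.6%; compound 2 `CC(C)c1ccc(-n2nc(-c3ccccc3)nc2CNc2ccc(C(=O)NO)cc2)cc1` with 52.6%; compound 3 `O=C(NO)c1ccc(NCc2nc(-c3ccccc3Cl)nn2-c2ccccc2)cc1` with 75%, all in an assay on Sf9 cells for inhibition of protein deacetylase HDAC6 (Homo sapiens), read by fluorescence, with a stated time of 40 min, tested at 100 nM; on this read-out lower numbers stand for less inhibition and higher numbers for more inhibition at the one concentration tested (going by the name of the read-out).

Compound 2 stands lowest of the three, beyond the scatter below both compound 3 and compound 1. Compound 4 `O=C(NO)c1ccc(NCc2nc(-c3ccccc3)nn2-c2ccc(F)cc2)cc1` is the unmeasured analogue; the change is fluoro in place of isopropyl on an aromatic carbon. For the measured compounds named here, the only measured step, a number 2.6 percentage points lower from compound 1 to compound 3 (within the scatter), concerns the other aryl ring and does not bear on this change. Compounds 1 and 3, which carry no group at this place, both give higher values than compound 2, so a rise is expected for compound 4, though its size is uncertain. The expected step is a number 15.4 percentage points higher from compound 2 to compound 4 (beyond the scatter), and compound 4 is estimated at 68%, between 50% and 85%.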

Compound 4, a percentage reported as inhibition, at one concentration (the size of the read-out at that concentration, not a potency): 67.6%
Compound 4: middle estimate off by 0.4 percentage points, on the high side, within the range that was stated.
By their numbers in this assay, from the lowest: compound 2; then compounds 4, 3 and 1 (each within the scatter of the next).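

In this assay, for the compounds shown here, this is the first reading of the position on an aromatic carbon para to a large group, since the earlier step lay at another place. Fluoro in place of isopropyl gives a number 15 percentage points higher from compound 2 to compound 4 (beyond the scatter), so the read-out responds to the group held here. Nothing available explains this difference. The compounds shown leave open how an amine, a carboxylic acid or a longer alkyl chain would read at this place. They also leave open whether the step would persist with 2-chlorophenyl or 4-methoxyphenyl at the other site.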